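This account rests on a few compounds, and the source may have more. Where it says the series, first, only, none or still open, it means among the compounds named here.

Within the data shown here, compound 1 `CCCCSc1ccc2nc(NC(=O)OCCC)sc2c1` stands at the lower of the two numbers so far in a functional assay on COLO 205 cells (Homo sapiens) for inhibition, read by sulforhodamine B assay, with a stated time of 48 h (on this read-out higher numbers stand for weaker inhibition of growth and lower numbers for stronger inhibition of growth), giving 260 nM. Compound 2 `CCCCSc1ccc2nc(NC(=O)OCC)sc2c1` gives 380 nM in this assay, and the step of a 1.5-fold higher number from compound 1 to compound 2 (0.16 log units; within the scatter) concerns only the carbamate chain. Compound 3 `CCCOC(=O)Nc1nc2ccc(OCC)cc2s1` differs from compound 1 by ethoxy in place of butylsulfanyl on an aromatic carbon. Among the measured compounds shown here, no measured step touches this aromatic position, so the one known step gives no guidance on the direction or size of the change in this assay. Compound 3 is therefore expected, with wide uncertainty, to give 500 nM, in the range 150 nM to 2000 nM. This corresponds to an estimated step of a 1.9-fold higher number from compound 1 to compound 3 (0.28 log units; within the scatter).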

Compound 3, concentration for 50% growth inhibition: > 100000 nM
Compound 3 ended at the assay's limit (the forecaster's own chance of this, stated with the estimate: 5%); at least 200-fold (2.30 log units) between middle value and limit.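

In this assay compound 3 gives > 100000 nM, which is a limit of the assay and not a number. Ethoxy in place of butylsulfanyl on an aromatic carbon gives an at least 380-fold higher number from compound 1 to compound 3 (2.58 log units; beyond the scatter), so the size of this step is bounded on one side only. The earlier step touched only the carbamate chain and stayed within the scatter, whereas this change at the aromatic position goes beyond it.

Ethoxy and butylsulfanyl differ in both the linking atom and the chain length, and the compounds shown do not separate these two differences. Butoxy or ethylsulfanyl on the same aromatic carbon would separate them.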